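The compounds below may be only part of what the source reports. "The series", "measured", "known", "first", "only" and "open" are said of these compounds alone.

Working notes on the series, continued.

The shared core of compound 1 `COc1ccc(-c2cc3ccccc3nc2/C=C/C(=O)c2ccc(Br)s2)cc1` carries a carbonyl bearing a 5-bromothiophen-2-yl group. In a functional assay on NCI-H460 cells (Homo sapiens) for antiproliferative activity, read by XTT assay, with a stated time of 72 h (on this read-out lower numbers stand for stronger inhibition and higher numbers for weaker inhibition), compound 1 gives 5170 nM. Compound 2 `COc1ccc(-c2cc3ccccc3nc2/C=C/C(=O)c2cnc(N)nc2C)cc1` keeps the core and swaps that group for a 2-amino-4-methylpyrimidin-5-yl. In this assay compound 2 returns only a limit, > 10000 nM, so its true position is not pinned down. The step of an at least 1.9-fold higher number from compound 1 to compound 2 (0.28 log units; that floor lies within the scatter) is therefore a floor rather than a number, since compound 2 sits at the limit of > 10000 nM in this assay, at which 1 of the 2 values shown sits.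

Compound 3 `COc1ccc(-c2cc3ccccc3nc2/C=C/C(=O)c2c[nH]c3ccccc23)cc1` is the next member: 1H-indol-3-yl in place of 2-amino-4-methylpyrimidin-5-yl on a carbonyl carbon. Among the compounds with values here, only the step from compound 1 to compound 2 bears on this change, and it records the loss of activity on moving away from the 5-bromothiophen-2-yl group. The indol-3-yl group brings back a ring system with a donor and no acceptors, so the expectation for compound 3 is a return toward the region of compound 1, that is a lower number than the limit of compound 2. The step of an at least 1.6-fold lower number from compound 2 to compound 3 (0.22 log units; that floor lies within the scatter) is the expected size of that return. For compound 3 the estimate in this assay is 6000 nM, with a range from 2000 nM to 20000 nM.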

Compound 3, half-maximal inhibitory concentration: 8010 nM
The estimate for compound 3 lay 1.3-fold (0.13 log units) below the measured number; low and high end bracket the measured number.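

In this assay, 1H-indol-3-yl in place of 5-bromothiophen-2-yl gives a 1.5-fold higher number from compound 1 to compound 3 (0.19 log units; within the scatter), so on this carbonyl carbon a group with one five-membered and one six-membered aromatic ring cannot be told apart from the 5-bromothiophen-2-yl group. The other change, 1H-indol-3-yl in place of 2-amino-4-methylpyrimidin-5-yl, gives an at least 1.2-fold lower number from compound 2 to compound 3 (0.09 log units; that floor lies within the scatter), which is only a floor and adds no firm separation at this place. Its true size cannot be read because compound 2 stands at a limit of the assay: the limit of > 10000 nM in this assay, at which 1 of the 3 values shown sits.

On these data alone, how far compound 2 truly lies from the other two compounds stays open, and so does whether the 2-amino-4-methylpyrimidin-5-yl group differs from the 1H-indol-3-yl group by more than the scatter. Also open, as far as these compounds go, is whether the hydrogen on the indole nitrogen matters, which a 1-methylindol-3-yl group on the same carbonyl carbon would address, and whether a plain phenyl ring or a carboxylic acid there would move the number beyond the scatter in this assay.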